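Swapping naphthalen-1-yl in compound 1: an expected step

A few compounds are considered here, and "the series" means these few. Any claim that something is new, unique, unknown or untested is made for them only; others in the source may bear on it.

Of the compounds shown here, three have been read so far in a functional assay on COLO 205 cells (Homo sapiens) for inhibition, read by sulforhodamine B assay, with a stated time of 48 h, tested at 50 uM (on this read-out lower numbers stand for less inhibition of growth and higher numbers for more inhibition of growth at the one concentration tested), on this series. Compound 1 `COc1cc(/C=C/C(=O)/C=C/c2cccc3ccccc23)ccc1OCc1cn(CCCOc2cc(=O)oc3ccccc23)nn1` gives 64% and stands at the top of the set, though within the scatter of compound 3 `COc1cc(/C=C/C(=O)/C=C/c2ccccc2)ccc1OCc1cn(CCOc2cc(=O)oc3ccccc23)nn1` at 54% in the same read-out. Compound 2 `COc1ccc(/C=C/C(=O)/C=C/c2ccc(OCc3cn(CCCCCOc4cc(=O)oc5ccccc45)nn3)c(OC)c2)cc1` gives 30% and lies clearly lower than compound 1, beyond the scatter.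

Compound 4 `COc1cc(/C=C/C(=O)/C=C/c2cc(OC)c(OC)c(OC)c2)ccc1OCc1cn(CCCOc2cc(=O)oc3ccccc23)nn1` differs from compound 1 in one place, on a double-bonded chain carbon bound to a double-bonded chain carbon, where 3,4,5-trimethoxyphenyl stands in place of naphthalen-1-yl (3,4,5-trimethoxyphenyl in place of naphthalen-1-yl on a double-bonded chain carbon bound to a double-bonded chain carbon).

Among the measured compounds shown here, the measured compounds differ from one another in more than one place, so no measured step isolates this change. Compound 3 carries another group at that place, together with a different chain, and still reads 54% in this assay so a large loss is not assumed. Compound 2 at 30% keeps the lower side of the range open. A small downward move, not beyond the scatter, is expected. The estimated change is a number 8 percentage points lower from compound 1 to compound 4 (within the scatter) on present evidence. For compound 4 the estimated value is 56% with an expected range from 36% to 74% until the measurement arrives.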

Compound 4, percent growth inhibition at one concentration: 74%
Compound 4: the middle estimate sits 18 percentage points below what was measured; low and high end bracket the measured number.
By their numbers in this assay, from the lowest: compound 2; then compounds 3, 1 and 4 (each within the scatter of the next, the first and the last beyond it).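

In this assay, among the compounds shown here, this pair gives the first reading of a single change on a double-bonded chain carbon bound to a double-bonded chain carbon: 3,4,5-trimethoxyphenyl in place of naphthalen-1-yl gives a number 10 percentage points higher from compound 1 to compound 4 (within the scatter). The printed step therefore shows that, with the rest of compound 1 held constant, two six-membered aromatic rings of carbon only can give way to one such ring and 3 hydrogen-bond acceptors without a difference beyond the scatter. No measured property accompanies this pair, so the data offer no account of the result.

Still open, as far as these compounds go, is how an amine or a carboxylic acid at this place would read on the core of compound 1, since both groups in this pair are aromatic and carry no net charge. Also open, from the compounds shown here alone, is whether the same exchange would stay within the scatter on a longer chain, and whether this result at the one concentration tested would carry over to other concentrations.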